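The source may report more compounds than this note shows. Statements on the series, on what has been measured and on what is new or still open speak of the compounds shown alone.

Working notes on a three-membered series with one open position.

Compound 1 `N#C/C(=C\c1ccccc1OS(=O)(=O)c1ccc([N+](=O)[O-])cc1)C(=O)Nc1nnc(Cc2ccc(F)cc2)s1`, compound 2 `N#C/C(=C\c1ccccc1OS(=O)(=O)c1ccc([N+](=O)[O-])cc1)C(=O)Nc1nnc(Cc2ccc(Cl)cc2)s1` and compound 3 `Cc1ccc(Cc2nnc(NC(=O)/C(C#N)=C/c3ccccc3OS(=O)(=O)c3ccc(Cl)cc3)s2)cc1` have been measured in a functional assay on HL-60 cells (Homo sapiens) for inhibition, read by CCK-8 assay, with a stated time of 48 h, tested at 20 uM; a higher number here means more inhibition of growth at the concentration tested, a lower number less inhibition of growth. Compound 1 gives 18%, compound 2 gives 34% and compound 3 gives 38%. Compound 3 and compound 2 lie within the usual scatter of each other, so nothing is read from their gap; the difference between their cores is not broken down here.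

One change is measured directly: from compound 2 to compound 1 the change is fluoro in place of chloro on an aromatic carbon, and in this assay it made a step of a number 16 percentage points lower from compound 2 to compound 1 (beyond the scatter), beyond the scatter.

Compound 4 `Cc1ccc(Cc2nnc(NC(=O)/C(C#N)=C/c3ccccc3OS(=O)(=O)c3ccc(F)cc3)s2)cc1` is not yet measured. It differs from compound 3 by fluoro in place of chloro on an aromatic carbon. The place reads the same as for the change from compound 2 to compound 1, though the wider cut differs, (4-chlorophenyl)sulfonyl to (4-fluorophenyl)sulfonyl in one case and 4-chlorobenzyl to 4-fluorobenzyl in the other, so it is the same kind of change on a different part of the molecule.

Among the measured compounds shown here, the expectation for compound 4 rests on the single measured instance, the step from compound 2 to compound 1 of a number 16 percentage points lower from compound 2 to compound 1 (beyond the scatter), and on the value of compound 3 of 38%; a downward step is expected, but with one instance only the size is uncertain, and the step from compound 3 to compound 4 is estimated at a number 12 percentage points lower from compound 3 to compound 4 (beyond the scatter). In this assay compound 4 is accordingly expected at about 26%, within a range of 12% to 40%.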

Compound 4, percent growth inhibition at one concentration: 11%
Beside the measured number, compound 4's estimate is 15 percentage points above it, outside the stated range (below it).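

In this assay the new step is a number 27 percentage points lower from compound 3 to compound 4 (beyond the scatter), so fluoro in place of chloro on an aromatic carbon again goes with less inhibition of growth, this time as (4-chlorophenyl)sulfonyl to (4-fluorophenyl)sulfonyl rather than as 4-chlorobenzyl to 4-fluorobenzyl. The two instances agree in direction and cannot be told apart in size: the same change on two cores in this assay, a number 16 percentage points lower (beyond the scatter) from compound 2 to compound 1 and a number 27 percentage points lower (beyond the scatter) from compound 3 to compound 4, 11 percentage points apart, within the scatter of two such steps This supports carrying the direction of the change between these two cores, but with only two instances, each on a different part of the molecule, it does not establish a rule for other cores, and it does not show why the change lowers the read-out.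

The compounds shown leave open whether the drop reflects something particular to fluoro or to the loss of chloro, which a bromo, a methoxy or a plain hydrogen at the same place on the aromatic ring could help to separate. Also open, from the compounds shown here alone, is whether the sulfonyl-side change gives a similar step when 4-chlorobenzyl rather than the methyl-bearing benzyl group is present elsewhere in the molecule.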